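Trimming a Benzylcarbamoyl Down to Methoxy

The source may hold more compounds than are shown below. What is called first, only, known or untested is meant among the compounds shown, and "the series" means these compounds.

Compound 1 `CC(C)Oc1ccc2c(c1)CC(c1nc3ccc(-c4ccnc(N)n4)cc3[nH]1)CO2`: "not determined" (no result reported)
Compound 2 `Nc1nccc(-c2ccc3nc(C4COc5ccc(C(=O)NCc6ccccc6)cc5C4)[nH]c3c2)n1`: 23 nM
Compound 3 `Cc1[nH]ncc1-c1ccc2nc(C3COc4ccccc4C3)[nH]c2c1`: "not determined" (no result reported)

Among the measured compounds shown here, compound 2 is the only one of the three with a number in an assay on cells for inhibition of Rho-associated protein kinase 2 (Homo sapiens); on this read-out higher numbers stand for weaker inhibition and lower numbers for stronger inhibition; for compound 1 and compound 3 no result was reported, so there is no step between measured compounds to lean on. Compound 4 `COc1ccc2c(c1)CC(c1nc3ccc(-c4ccnc(N)n4)cc3[nH]1)CO2` differs from compound 2 in a single place: methoxy in place of benzylcarbamoyl on an aromatic carbon. With nothing else to go on, a modest step toward weaker inhibition is expected, estimated as a 2.0-fold higher number from compound 2 to compound 4 (0.29 log units; within the scatter), though a result within the usual scatter of compound 2 would not surprise. For compound 4 the expected value in this assay is 45 nM, with a range from 12 nM to 180 nM.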

Compound 4, half-maximal inhibitory concentration: 99 nM
The estimate for compound 4 lay 2.2-fold (0.34 log units) below the measured number; the range from low to high includes it.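

In this assay, among the compounds shown here, the change gives the first readable comparison at this position: a 4.3-fold higher number from compound 2 to compound 4 (0.63 log units; beyond the scatter), a step beyond the usual scatter. Giving up benzylcarbamoyl, with its aromatic ring, for the much smaller methoxy weakens inhibition, yet compound 4 still gives a measurable 99 nM in this read-out. Nothing measured here gives a reason for the step. From the compounds shown here alone, it remains open whether the ring or the amide part of benzylcarbamoyl matters more, and whether a methylcarbamoyl, a carboxylic acid or an amine on this aromatic carbon would land nearer compound 2 or compound 4.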